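Para substituent swap on the benzylamine: compound 3

The compounds below may be only part of what the source reports. "The series", "measured", "known", "first", "only" and "open" are said of these compounds alone.

Measured so far:
- compound 1 `COc1cc(/C=C/c2nc(NCc3ccccc3)c3sccc3n2)cc(OC)c1OC`: 8260 nM in a functional assay on RAW264.7 cells (Mus musculus) for inhibition, read by Griess assay, with stated times of 1 h and 24 h; on this read-out higher numbers stand for weaker inhibition and lower numbers for stronger inhibition
- compound 2 `COc1ccc(CNc2nc(/C=C/c3cc(OC)c(OC)c(OC)c3)nc3ccsc23)cc1`: 7540 nM in this assay

Among the compounds with values here, compound 2 gives the lowest of the two numbers in this assay, but its only neighbour is compound 1, and the step of a 1.1-fold lower number from compound 1 to compound 2 (0.04 log units; within the scatter) lies within the scatter, so the two compounds cannot be told apart on these data.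

Compound 3 `COc1cc(/C=C/c2nc(NCc3ccc(Cl)cc3)c3sccc3n2)cc(OC)c1OC` is not yet measured. It differs from compound 2 in one place: chloro in place of methoxy on an aromatic carbon.

Within the data shown here, only one measured step touches this part of the molecule, a 1.1-fold lower number from compound 1 to compound 2 (0.04 log units; within the scatter), which changed the same aromatic carbon from hydrogen to methoxy and was within the scatter. Among the measured compounds shown here, no measured step exchanges methoxy for chloro anywhere, so there is no direct precedent for the size or direction of the change.

On that basis no step beyond the scatter is expected, and the estimated step is a 1.1-fold lower number from compound 2 to compound 3 (0.03 log units; within the scatter). Compound 3 is therefore expected to give about 7000 nM in this assay, with a range from 3500 nM to 15000 nM.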

Compound 3, half-maximal inhibitory concentration: 9050 nM
The estimate for compound 3 lay 1.3-fold (0.11 log units) below the measured number, and the stated range covers the measured number.
By their numbers in this assay, from the lowest: compounds 2, 1 and 3 (each within the scatter of the next).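

In this assay, a third group on this aromatic carbon, para to a large group, adds no separation: chloro in place of methoxy gives a 1.2-fold higher number from compound 2 to compound 3 (0.08 log units; within the scatter), and chloro in place of hydrogen gives a 1.1-fold higher number from compound 1 to compound 3 (0.04 log units; within the scatter). Within the data shown here, the one earlier step compared only hydrogen and methoxy, whereas hydrogen, methoxy and chloro now form a set of three that cannot be told apart at this carbon, and each pair among them lies within the scatter. Nothing at hand offers an explanation for this reading.

Still open, from the compounds shown here alone, is whether an amine, a carboxylic acid or a longer chain on this carbon would move the number in this read-out beyond the scatter of these three compounds, or whether the carbon tolerates such groups just as it does hydrogen, methoxy and chloro. The steps shown all touch this one carbon, and what a change elsewhere on the shared core would do remains open.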